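Lengthening the Alkyl Amide Chain of Compound 1

A few compounds are considered here, and "the series" means these few. Any claim that something is new, unique, unknown or untested is made for them only; others in the source may bear on it.

Among the measured compounds shown here, compound 1 `CCCCCCCCCCCCNC(=O)[C@@H](NC(=O)c1cc2ccccc2o1)[C@@H](C)O` is one of two compounds measured in a functional assay on A-431 cells (Homo sapiens) for cytotoxicity, read by MTT assay, with a stated time of 48 h; a higher number here means a weaker inhibitor, a lower number a stronger inhibitor. For the measured compounds named here, compound 1 gives 20000 nM, the only number among the two values shown. Compound 2 `CCCCCCCCCCCCNC(=O)[C@@H](NC(=O)/C=C/c1ccccc1)[C@@H](C)O` reaches only a limit of the assay, > 200000 nM. Going by the values given here, the single measured step, an at least 10-fold higher number from compound 1 to compound 2 (1.00 log units; beyond the scatter), concerns the group on the carbonyl carbon, and the limit of > 200000 nM in this assay, at which 1 of the 2 values shown sits, is the limit at which compound 2 sits. Compound 3 `CCCCCCCCCCCCCCCCCCNC(=O)[C@@H](NC(=O)c1cc2ccccc2o1)[C@@H](C)O` differs from compound 1 at the far end of the chain: hexyl in place of hydrogen on a saturated chain carbon, ten or more bonds along the chain from an amide-type nitrogen. Among the compounds with values here, no measured step touches that position; the step from compound 1 to compound 2 offers no guide to its size or direction. With nothing in the data pointing either way, the chain extension is expected to leave the value within the scatter, no change at the digits printed from compound 1 to compound 3 (within the scatter). Compound 3 is therefore estimated at 20000 nM, within 5000 nM to 80000 nM.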

Compound 3, half-maximal inhibitory concentration: 78800 nM
For compound 3 the middle estimate is 3.9-fold (0.60 log units) below the measured one, within the range that was stated.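

In this assay, hexyl in place of hydrogen on a saturated chain carbon, ten or more bonds along the chain from an amide-type nitrogen, gives a 3.9-fold higher number from compound 1 to compound 3 (0.60 log units; beyond the scatter), so this position does register in the read-out. The earlier compounds shown here kept this chain fixed and varied only the group on the carbonyl carbon, whereas here, with 1-benzofuran-2-yl kept, the longer chain gives a weaker inhibitor. Nothing in the data shown gives a reason for this step.

On these data alone, with a single step at this position, it remains open whether a shorter chain or a chain extended by fewer carbons than hexyl would follow the same direction. Also open, as far as these compounds go, are the effect of an amine or a carboxylic acid on the chain and whether hexyl would act alike with 2-phenylethenyl on the carbonyl carbon.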